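Shifting a chloro group on the amide phenyl ring

A few compounds are considered here, and "the series" means these few. Any claim that something is new, unique, unknown or untested is made for them only; others in the source may bear on it.

Compound 2 `Cc1ccc(NC(=O)c2ccc(/N=N\c3c[nH]c4ccccc34)cc2)cc1`: 25400 nM
Compound 1 `O=C(Nc1ccccc1)c1ccc(/N=N\c2c[nH]c3ccccc23)cc1`: 103000 nM
Compound 3 `O=C(Nc1ccccc1Cl)c1ccc(/N=N\c2c[nH]c3ccccc23)cc1`: 120000 nM

In a functional assay on HCT-116 cells (Homo sapiens) for inhibition, read by MTT assay, with a stated time of 72 h (on this read-out higher numbers stand for weaker inhibition and lower numbers for stronger inhibition), compound 2 gives the lowest of the three numbers; the nearest is compound 1 with a 4.1-fold lower number from compound 1 to compound 2 (0.61 log units; beyond the scatter) read in reverse, and the furthest is compound 3, reached by a 4.7-fold higher number from compound 2 to compound 3 (0.67 log units; beyond the scatter). Compound 4 `O=C(Nc1cccc(Cl)c1)c1ccc(/N=N\c2c[nH]c3ccccc23)cc1` has not yet been measured in this assay. It differs from compound 2 by 3-chlorophenyl in place of 4-methylphenyl on an amide-type nitrogen. For the measured compounds named here, two measured steps bear on this change. The step of a 1.2-fold higher number from compound 1 to compound 3 (0.07 log units; within the scatter) shows that adding chloro to the plain phenyl ring of compound 1 leaves the number where it was, within the scatter. The step of a 4.7-fold higher number from compound 2 to compound 3 (0.67 log units; beyond the scatter) shows that exchanging 4-methylphenyl for 2-chlorophenyl gives a modestly higher number. Since 3-chlorophenyl is again a chlorophenyl ring without the methyl group, compound 4 is expected to fall in this assay at a higher number than compound 2, by a step of about the size seen from compound 2 to compound 3, though the step in a 1.2-fold higher number from compound 1 to compound 3 (0.07 log units; within the scatter) leaves open whether the chloro position matters at all. The estimate for compound 4 is therefore 80000 nM, with a range from 30000 nM to 200000 nM, corresponding to an expected step of a 3.1-fold higher number from compound 2 to compound 4 (0.50 log units; beyond the scatter).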

Compound 4, half-maximal inhibitory concentration: 80000 nM
For compound 4 middle estimate and measured number coincide at the digits printed; the measured number falls inside the stated range.
By their numbers in this assay, from the lowest: compound 2; then compounds 4, 1 and 3 (each within the scatter of the next).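

In this assay, 3-chlorophenyl in place of 2-chlorophenyl on the amide-type nitrogen gives no difference that can be read (a 1.5-fold lower number from compound 3 to compound 4 (0.18 log units; within the scatter)), so the two chloro placements shown cannot be told apart. Chloro in place of hydrogen on the plain phenyl ring of compound 1 likewise stays within the scatter at this second placement (a 1.3-fold lower number from compound 1 to compound 4 (0.11 log units; within the scatter)), which puts compounds 1, 3 and 4 together as one group of numbers. The exchange of 4-methylphenyl for 3-chlorophenyl (a 3.1-fold higher number from compound 2 to compound 4 (0.50 log units; beyond the scatter)) goes the same way as the exchange for 2-chlorophenyl, so among these four compounds only compound 2, with its 4-methylphenyl ring, stands apart, and no compound shown goes against this.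

The compounds shown leave open whether the number of compound 2 comes with the methyl group as such or with its place on the ring, and whether a methoxy group, an amine or a carboxylic acid on the same ring would read like compound 2 or like the chlorophenyl compounds. No measurement given here accounts for these numbers.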